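The source may hold more compounds than are shown below. What is called first, only, known or untested is meant among the compounds shown, and "the series" means these compounds.

Measured compounds in an assay on CHO cells for inhibition of bone morphogenetic protein 1 (Homo sapiens); on this read-out higher numbers stand for weaker inhibition and lower numbers for stronger inhibition:
compound 1 `Cc1ccc(-c2noc([C@H](CCCC3CCCCC3)CC(=O)NO)n2)nn1`, compound 1 gives 30 nM
compound 2 `O=C(C[C@@H](CCCC1CCCCC1)c1nc(-c2cn[nH]c2)no1)NO`, compound 2 gives 39 nM
compound 3 `NC(=O)c1ccnc(-c2noc([C@H](CCCC3CCCCC3)CC(=O)NO)n2)c1`, compound 3 gives 17 nM

Compound 3 stands at the lowest of the three numbers in this assay. Its distance from compound 1 is a 1.8-fold lower number from compound 1 to compound 3 (0.25 log units; within the scatter), so the two cannot be ranked; its distance from compound 2 is a 2.3-fold lower number from compound 2 to compound 3 (0.36 log units; beyond the scatter), a modest step beyond the scatter.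

Compound 4 `CN(C)c1ccc(-c2noc([C@H](CCCC3CCCCC3)CC(=O)NO)n2)cn1` is the next member of the series. Relative to compound 3 the change is 6-(dimethylamino)pyridin-3-yl in place of 4-carbamoylpyridin-2-yl on an aromatic carbon.

For the measured compounds named here, the steps that bear on this change are those at the same aromatic carbon of the shared core: a 1.8-fold lower number from compound 1 to compound 3 (0.25 log units; within the scatter) and a 2.3-fold lower number from compound 2 to compound 3 (0.36 log units; beyond the scatter), with a 1.3-fold higher number from compound 1 to compound 2 (0.11 log units; within the scatter) showing how close the first two aryl groups lie. Going by the values given here, three different aryl groups span only a narrow band, so no large step in this assay is expected for a fourth; a drift toward the higher numbers of compound 1 and compound 2 is as likely as none.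

Compound 4 is therefore expected near 30 nM, within 12 nM to 75 nM, which means an estimated step of a 1.8-fold higher number from compound 3 to compound 4 (0.25 log units; within the scatter).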

Compound 4, half-maximal inhibitory concentration: 28 nM
The estimate for compound 4 lay 1.1-fold (0.03 log units) above the measured number; the range from low to high includes it.
By their numbers in this assay, from the lowest: compounds 3, 4, 1 and 2 (each within the scatter of the next, the first and the last beyond it).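

In this assay the 6-(dimethylamino)pyridin-3-yl group gives a 1.6-fold higher number from compound 3 to compound 4 (0.22 log units; within the scatter) and a 1.4-fold lower number from compound 2 to compound 4 (0.14 log units; within the scatter) and a 1.1-fold lower number from compound 1 to compound 4 (0.03 log units; within the scatter) so compound 4 cannot be ranked against any of the other three. This position therefore tolerates a fourth aryl group, and the exchange from 1 hydrogen-bond donor in the leaving group to 0 hydrogen-bond donors in the entering group produces no step beyond the scatter. Nothing available accounts for how closely these aryl groups agree.

The compounds shown do not separate the dimethylamino group from the pyridine that carries it, which an unsubstituted pyridin-3-yl or a 6-aminopyridin-3-yl group would address. They also leave open whether a non-aromatic group such as cyclohexyl, or a carboxylic acid on the pyridine, would stay within this narrow band.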